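The compounds below may be only part of what the source reports. "The series", "measured", "known", "first", "only" and "open" are said of these compounds alone.

Compounds measured so far in an ADME assay on Huh7.5.1 cells (Homo sapiens) for cytotoxicity, read by ATP content, with a stated time of 48 h (a higher number here means that more compound is tolerated, a lower number that less compound is tolerated), are these
- compound 1 `Cc1oc(-c2c(C)c(C)c(C)c(C)c2C)nc1CN1CCC(C(=O)NCCCN2C[C@H](C)C[C@H](C)C2)CC1` gives 8180 nM
- compound 2 `Cc1ccccc1-c1nc(CN2CCC(C(=O)NCCCN3[C@H](C)CCC[C@@H]3C)CC2)c(C)o1` gives 21300 nM
- compound 3 `CC[C@@H]1C[C@H](CC)CN(CCCNC(=O)C2CCN(Cc3nc(-c4c(F)cccc4F)oc3C)CC2)C1` gives 12600 nM

Compound 2 has the highest number of the three, but its gap to compound 3 lies within the scatter, so those two cannot be separated. Only the gap to compound 1 lies beyond the scatter, with compound 1 lower.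

Compound 4 `CCCN(CCC)CCNC(=O)C1CCN(Cc2nc(-c3ccccc3C)oc2C)CC1` is the next to consider. Relative to compound 2, the change (dipropylamino in place of (2,6-dimethylpiperidin-1-yl)methyl on a saturated chain carbon, two bonds along the chain from an amide-type nitrogen) places dipropylamino on a saturated chain carbon, two bonds along the chain from an amide-type nitrogen.

For the measured compounds named here, no two measured compounds differ in one place only, so this change has no direct precedent in this assay and the expectation rests on the narrow spread of the series. That spread runs from compound 1 at 8180 nM to compound 2 at 21300 nM and gives no reason to expect a large move. The estimated size of the change (a 1.2-fold lower number from compound 2 to compound 4 (0.07 log units; within the scatter)) is a slight decrease, within the scatter. For compound 4 the expected value is 18000 nM with an estimated range from 8000 nM to 40000 nM in this series.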

Compound 4, half-maximal cytotoxic concentration: 30500 nM
Estimate against measurement, compound 4: 1.7-fold (0.23 log units) below; low and high end bracket the measured number.
By their numbers in this assay, from the lowest: compounds 1, 3, 2 and 4 (each within the scatter of the next, the first and the last beyond it).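

In this assay, for the compounds shown here, the first single-place pair gives a 1.4-fold higher number from compound 2 to compound 4 (0.16 log units; within the scatter), which lies within the scatter, so compound 2 and compound 4 cannot be separated. On a saturated chain carbon, two bonds along the chain from an amide-type nitrogen, dipropylamino can therefore replace (2,6-dimethylpiperidin-1-yl)methyl, giving up the six-membered ring and both defined stereocentres, with no readable shift in this read-out. Nothing available explains this outcome.

A single pair does not show whether the same holds for a different group at this place, such as a carboxylic acid or a morpholine ring. Compound 1 and compound 3 each differ from compound 2 in more than one place, so the separate contributions of their changes remain unresolved.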